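Swapping an alkyl chain for a fluorinated ring on an amide core

This account rests on a few compounds, and the source may have more. Where it says the series, first, only, none or still open, it means among the compounds named here.

Measured compounds:
- Compound 1, `NC(N)=NC(=O)c1nc(Cl)c(NCc2ccccc2Cl)nc1N`: 90%
- Compound 2, `CCCNc1nc(N)c(C(=O)N=C(N)N)nc1Cl`: 91%

Both were tested in an assay for inhibition of acid-sensing ion channel 3 (Homo sapiens), read by patch clamp, tested at 20 uM; a higher number here means more inhibition at the concentration tested (going by the name of the read-out), a lower number less inhibition. The two numbers lie close together, the step being a number 1 percentage points higher from compound 1 to compound 2 (within the scatter), so the two cannot be told apart.

Compound 3, `NC(N)=NC(=O)c1nc(Cl)c(NCc2ccccc2F)nc1N`, has not yet been measured. It differs from compound 2 as follows: 2-fluorophenyl in place of ethyl on a saturated chain carbon bound to a nitrogen on an aromatic ring. Among the measured compounds shown here, the only measured step that bears on this change is the one between compound 1 and compound 2, where a 2-chlorophenyl gave way to ethyl with a shift of a number 1 percentage points higher from compound 1 to compound 2 (within the scatter). Since compound 1 carries a ring very like the one entering here and sits so close to compound 2, no step beyond the scatter is expected in this assay, with a number 1 percentage points lower from compound 2 to compound 3 (within the scatter) as the estimated step. Compound 3 is therefore expected to give about 90%, within a range of 80% to 97%.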

Compound 3, a percentage reported as inhibition, at one concentration (the size of the read-out at that concentration, not a potency): 92%
Compound 3: middle estimate off by 2 percentage points, on the low side; the range from low to high includes it.
By their numbers in this assay, from the lowest: compounds 1, 2 and 3 (each within the scatter of the next).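

In this assay, putting a 2-fluorophenyl in place of ethyl on this saturated chain carbon leaves no difference that can be read (a number 1 percentage points higher from compound 2 to compound 3 (within the scatter)), so this position holds a fluorinated ring as well as a short alkyl chain at the concentration tested. Changing the halogen on the ring, with fluoro in place of chloro on an aromatic carbon, also stays inside the usual variation (a number 2 percentage points higher from compound 1 to compound 3 (within the scatter)), which means that the three compounds cannot be told apart. Nothing available here explains why these changes leave the reading in place.

On these data alone, whether an amine or a carboxylic acid on the ring, or a much longer chain, would hold the reading remains open. A reading at one concentration also leaves open whether the three compounds differ in potency.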